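Trifluoroethyl for oxetane, tested on a second core

The compounds below may be only part of what the source reports. "The series", "measured", "known", "first", "only" and "open" are said of these compounds alone.

Compound 1, `COc1cc(-c2nnc3c(OC4COC4)cc(-c4ccc5[nH]ccc5c4)cn23)cc(OC)c1OC`, gives 5370 nM in a functional assay on HCT-116 cells (Homo sapiens) for antiproliferative activity, read by MTT assay, with a stated time of 48 h; on this read-out higher numbers stand for weaker inhibition and lower numbers for stronger inhibition.
Compound 2, `COc1cc(-c2nnc3c(OCC(F)(F)F)cc(-c4ccc5[nH]ccc5c4)cn23)cc(OC)c1OC`, gives 900 nM in this assay.
Compound 3, `COc1cc(-c2nnc3c(OC4COC4)cc(-c4ccc5c(ccn5C)c4)cn23)cc(OC)c1OC`, gives 1290 nM in this assay.

All three compounds share a common core; they differ only in a pair of small substituents. The first point of variation is a group on an oxygen attached to an aromatic ring, described as 2,2,2-trifluoroethyl in place of oxetan-3-yl on an oxygen on an aromatic ring. This exchange was made once already among the measured compounds, and it produced a 6.0-fold lower number from compound 1 to compound 2 (0.78 log units; beyond the scatter).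

The second point of variation is on an aromatic nitrogen of a five-membered ring, described as methyl in place of hydrogen on an aromatic nitrogen. That exchange gave a 4.2-fold lower number from compound 1 to compound 3 (0.62 log units; beyond the scatter). Compound 2 and compound 3 sit close together, and their two values lie within the usual scatter of one another, so no order between them can be read.

Compound 4, `COc1cc(-c2nnc3c(OCC(F)(F)F)cc(-c4ccc5c(ccn5C)c4)cn23)cc(OC)c1OC`, has not been measured. Compared with compound 3, it carries 2,2,2-trifluoroethyl in place of oxetan-3-yl on an oxygen on an aromatic ring. The "place" at which this group is exchanged is the same, word for word, as it was between compound 1 and compound 2, so this is the same change placed on the core of compound 3 rather than on the core of compound 1. The expectation is therefore that compound 4 improves on compound 3 by about as much as was seen before, because of a 6.0-fold lower number from compound 1 to compound 2 (0.78 log units; beyond the scatter), with room for the two cores to respond differently. On this basis the step from compound 3 to compound 4 is estimated at a 5.2-fold lower number from compound 3 to compound 4 (0.71 log units; beyond the scatter). For compound 4 the estimated result in this assay is 250 nM, with a likely range from 80 nM to 800 nM.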

Compound 4, half-maximal inhibitory concentration: 483 nM
Beside the measured number, compound 4's estimate is 1.9-fold (0.29 log units) below it, within the range that was stated.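

Placing 2,2,2-trifluoroethyl in place of oxetan-3-yl on the core of compound 3 gives a 2.7-fold lower number from compound 3 to compound 4 (0.43 log units; beyond the scatter) in this assay, so the change points the same way on both cores, and the sizes of the two steps cannot be told apart: the same change on two cores in this assay, a 6.0-fold lower number (0.78 log units; beyond the scatter) from compound 1 to compound 2 and a 2.7-fold lower number (0.43 log units; beyond the scatter) from compound 3 to compound 4, 2.2-fold (0.35 log units) apart, within the scatter of two such steps. The methyl on the aromatic nitrogen gives a less clear result, since a 1.9-fold lower number from compound 2 to compound 4 (0.27 log units; within the scatter) does not stand out from repeat-measurement noise, yet this step also cannot be told apart from its counterpart on the other core: the same change on two cores in this assay, a 4.2-fold lower number (0.62 log units; beyond the scatter) from compound 1 to compound 3 and a 1.9-fold lower number (0.27 log units; within the scatter) from compound 2 to compound 4, 2.2-fold (0.35 log units) apart, within the scatter of two such steps. These four compounds therefore show that the oxygen substituent exchange carried over from one core to the other within this small set, but they do not show that it would carry to further cores, and they do not explain why either change acts as it does.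

The compounds shown leave open how other groups on the same oxygen would behave, such as a plain ethyl or a cyclobutyl ring in place of 2,2,2-trifluoroethyl. They also leave open whether a longer chain on the aromatic nitrogen, such as propyl, would follow the methyl, and whether these steps would hold on cell lines other than the one used here.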